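Swapping the bis(methylsulfonyl)amino group for an oxadiazole

The compounds below may be only part of what the source reports. "The series", "measured", "known", "first", "only" and "open" are said of these compounds alone.

Three compounds share one core and differ only at a single aromatic carbon of the pyridine-bearing end. Compound 1 `CC(C)(C)c1ccc(NC(=O)c2ccc(-c3ccccn3)cc2)cc1` carries hydrogen there and gives 8 nM in a functional assay for antagonist activity at transient receptor potential cation channel subfamily V member 1 (Rattus norvegicus); on this read-out higher numbers stand for weaker inhibition and lower numbers for stronger inhibition. Compound 2 `CCS(=O)(=O)Nc1cccnc1-c1ccc(C(=O)Nc2ccc(C(C)(C)C)cc2)cc1` carries an (ethylsulfonyl)amino group and gives 4 nM. Compound 3 `CC(C)(C)c1ccc(NC(=O)c2ccc(-c3ncccc3N(S(C)(=O)=O)S(C)(=O)=O)cc2)cc1` carries a bis(methylsulfonyl)amino group and gives 0.4 nM, the lowest of the three numbers. The steps from compound 1 to compound 2 a 2.0-fold lower number from compound 1 to compound 2 (0.30 log units; within the scatter) and from compound 1 to compound 3 a 20-fold lower number from compound 1 to compound 3 (1.30 log units; beyond the scatter) show that the two sulfonyl-bearing groups are not equal, and the step of a 10-fold lower number from compound 2 to compound 3 (1.00 log units; beyond the scatter) confirms the difference beyond the scatter.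

Compound 4 `CC(C)(C)c1ccc(NC(=O)c2ccc(-c3ncccc3-c3nnco3)cc2)cc1` replaces that group: 1,3,4-oxadiazol-2-yl in place of bis(methylsulfonyl)amino on an aromatic carbon. Going by the values given here, no measured pair bears on an oxadiazole at this place; the three steps only show that a substituent here can lower the number, with the bis(methylsulfonyl)amino group of compound 3 doing so most. The new group differs from it in every counted respect, so a move back toward compound 1 is expected rather than a further gain. For compound 4 the estimated result is 3 nM, within 0.8 nM to 12 nM. The expected step of a 7.5-fold higher number from compound 3 to compound 4 (0.88 log units; beyond the scatter) is thus modest but beyond the scatter.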

Compound 4, half-maximal inhibitory concentration: 59 nM
For compound 4 the middle estimate is 20-fold (1.29 log units) below the measured one, outside the stated range (above it).
By their numbers in this assay, from the lowest: compound 3; then compounds 2 and 1 (each within the scatter of the next); then compound 4.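

Replacing hydrogen with 1,3,4-oxadiazol-2-yl gives a 7.4-fold higher number from compound 1 to compound 4 (0.87 log units; beyond the scatter) in this assay, so a substituent on this aromatic carbon can raise the number as well as lower it, which compounds 2 and 3 alone did not show. The gap to the sulfonyl-bearing groups is wider, with a 15-fold higher number from compound 2 to compound 4 (1.17 log units; beyond the scatter) and a 150-fold higher number from compound 3 to compound 4 (2.17 log units; beyond the scatter), so the groups shown at this one place span a broad range of numbers, and compound 4 now marks its high end. Going by these compounds alone, the change takes out a group with no ring and brings in a five-membered aromatic ring with 3 hetero atoms, but no information at hand says why this exchange raises the number so far.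

On these data alone, whether the rise belongs to the oxadiazole alone or to five-membered aromatic rings at this place in general stays open, since a thiazole or a 1,2,4-triazole here would be needed to tell the two apart. As far as these compounds go, it also stays open where a plain amine or a carboxylic acid on this carbon would fall in the range between compound 3 and compound 4.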